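A few compounds are considered here, and "the series" means these few. Any claim that something is new, unique, unknown or untested is made for them only; others in the source may bear on it.

Working notes on the shared core. Compound 2 `O=C(C1CCC(F)(F)CC1)N1CCc2nc(C#Cc3ccccc3)sc2C1` carries a 4,4-difluorocyclohexyl group on the amide carbonyl. In an assay on HEK293 cells for negative allosteric modulation of metabotropic glutamate receptor 5 (Homo sapiens), read by FLIPR, with a stated time of 1 h (on this read-out lower numbers stand for stronger inhibition and higher numbers for weaker inhibition), compound 2 gives only the limit > 10000 nM, so no number is known for it. Among the compounds with values here, its one measured neighbour, compound 1 `CC1CC1C(=O)N1CCc2nc(C#Cc3ccccc3)sc2C1`, with 2-methylcyclopropyl in the same place, also sits at a limit: in this assay compound 1 gives > 10000 nM. The step that the two limits leave unreadable from compound 1 to compound 2 is therefore not readable, and the only thing shown is the limit of > 10000 nM in this assay, at which 2 of the 2 values shown sit. Compound 3 `O=C(c1cccc(Cl)c1)N1CCc2nc(C#Cc3ccccc3)sc2C1` differs from compound 2 by 3-chlorophenyl in place of 4,4-difluorocyclohexyl on a carbonyl carbon. Within the data shown here, no measured step bears on an aromatic group in this place, and the two limits say nothing about size or direction of the change in this assay. Compound 3 is estimated at 2000 nM, between 200 nM and 10000 nM, which would mean an expected step of an at least 5.0-fold lower number from compound 2 to compound 3 (0.69 log units; beyond the scatter).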

Compound 3, half-maximal inhibitory concentration: > 10000 nM
Compound 3 ended at the assay's limit (the forecaster's own chance of this, stated with the estimate: 45%); at least 5.0-fold (0.69 log units) between middle value and limit.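

In this assay compound 3 gives > 10000 nM, which is a limit and not a number. Within the data shown here, no step among compound 1, compound 2 and compound 3 can be read: the limit of > 10000 nM in this assay, at which 3 of the 3 values shown sit. The compounds shown leave open whether any group on this carbonyl carbon gives a measurable value in this assay.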